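The source may report more compounds than this note shows. Statements on the series, on what has been measured and on what is new or still open speak of the compounds shown alone.

Measured so far:
compound 1 `COc1ccc(NS(=O)(=O)/C=C/c2c(F)c(F)c(F)c(F)c2F)cc1F`: 10000 nM
compound 2 `COc1cc(OC)c(/C=C/S(=O)(=O)Nc2ccc(OC)c(F)c2)c(OC)c1`: 75 nM
compound 3 `COc1ccc(NS(=O)(=O)/C=C/c2c(OC)cc(OCCCC(=O)O)cc2OC)cc1N`: 10000 nM

In a functional assay on K562 cells (Homo sapiens) for cytotoxicity, read by trypan blue exclusion, with a stated time of 96 h (on this read-out higher numbers stand for weaker inhibition and lower numbers for stronger inhibition), compound 2, at 75 nM, has the lowest of the three numbers, and its gaps to compound 1 and to compound 3 both lie beyond the scatter. Going by the values given here, no two measured compounds differ in only one place, so no single change has yet been measured on its own.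

The next compound is compound 4 `COC(=O)CNc1cc(NS(=O)(=O)/C=C/c2c(OC)cc(OC)cc2OC)ccc1OC`. It carries ((methoxycarbonyl)methyl)amino in place of fluoro on an aromatic carbon, ortho to a methoxy group: ((methoxycarbonyl)methyl)amino in place of fluoro on an aromatic carbon. The expectation rests on compound 2 at 75 nM as the closest measured structure. Compound 3, at 10000 nM, differs from compound 4 in more than one place and gives no direct guide, though it leaves a real risk toward higher numbers. No step beyond the scatter is expected in this assay. The estimated step is a 1.3-fold higher number from compound 2 to compound 4 (0.12 log units; within the scatter). For compound 4 the expected value is 100 nM, with an estimated range of 15 nM to 1000 nM.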

Compound 4, half-maximal inhibitory concentration: 350 nM
The estimate for compound 4 lay 3.5-fold (0.54 log units) below the measured number; the measured number falls inside the stated range.
By their numbers in this assay, from the lowest: compound 2; then compound 4; then compounds 1 and 3 (each within the scatter of the next).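

In this assay, the aromatic carbon ortho to a methoxy group now has a single measured change: ((methoxycarbonyl)methyl)amino in place of fluoro gives a 4.7-fold higher number from compound 2 to compound 4 (0.67 log units; beyond the scatter) and lies beyond the scatter. This shows that the position responds to the exchange, yet the step is modest, and compound 4 still reads 350 nM with the larger group in place. No supporting measurement bears on why the number rises.

A single pair cannot show whether the step follows from losing fluoro or from some part of the entering group. As far as these compounds go, a hydroxy group, a methylamino group or a longer ester-bearing chain on this carbon would help separate those parts, while the effect of the same exchange on other cores remains open.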